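A few compounds are considered here, and "the series" means these few. Any claim that something is new, unique, unknown or untested is made for them only; others in the source may bear on it.

The measured compounds:
- compound 1, `COc1ccc(/C=C2\NC(=O)N(CCCCN3CCN(c4ccccc4OC)CC3)C2=O)cc1OC`, in an assay on CHO cells for displacement of a labelled ligand from 5-hydroxytryptamine receptor 7 (Homo sapiens), read by scintillation counting, with a stated time of 60 min (on this read-out lower numbers stand for stronger inhibition and higher numbers for weaker inhibition), compound 1 gives 16 nM
- compound 2, `COc1ccc(/C=C2\NC(=O)N(CCCCN3CCN(c4cccc(Cl)c4Cl)CC3)C2=O)cc1OC`; compound 2 gives 0.8 nM
- compound 3, `COc1ccc(/C=C2\NC(=O)N(CCCCN3CCN(c4ncccn4)CC3)C2=O)cc1OC`; compound 3 gives 933 nM

Compound 1 stands second highest of the three numbers. Compound 2 lies nearest, with a 20-fold lower number from compound 1 to compound 2 (1.30 log units; beyond the scatter); compound 3 lies furthest, with a 58-fold higher number from compound 1 to compound 3 (1.77 log units; beyond the scatter). Between the two other compounds the gap is wider still: a 1200-fold higher number from compound 2 to compound 3 (3.07 log units; beyond the scatter).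

Compound 4, `COc1ccc(/C=C2\NC(=O)N(CCCCN3CCN(c4ccccc4OC)CC3)C2=O)cc1OC1CCCC1`, differs from compound 1 in one place: cyclopentyl in place of methyl on an oxygen on an aromatic ring. All three measured steps concern the group on the amine nitrogen in the ring, a different part of the shared core from the oxygen on the aromatic ring where compound 4 changes. They show that this assay can move a great deal when one group is swapped, but none of them tests the change that leads to compound 4, so they give no direction for it. Within the data shown here, with no step bearing on it, the expectation for compound 4 in this assay is a number close to that of compound 1, and the step from compound 1 to compound 4 is estimated as a 1.6-fold higher number from compound 1 to compound 4 (0.19 log units; within the scatter), a change that may well stay within the usual scatter. Compound 4 is therefore expected to give about 25 nM, in a range from 6 nM to 100 nM.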

Compound 4, inhibition constant: 1 nM
Estimate against measurement, compound 4: 25-fold (1.40 log units) above; the whole stated range lies above it.
By their numbers in this assay, from the lowest: compounds 2 and 4 (each within the scatter of the next); then compound 1; then compound 3.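

The oxygen on the aromatic ring proves to be a second place where this assay responds strongly, with cyclopentyl in place of methyl giving a 16-fold lower number from compound 1 to compound 4 (1.20 log units; beyond the scatter) as a large step beyond the scatter. The earlier compounds shown here showed such movement only for the group on the amine nitrogen in the ring, so the number also depends on a part of the molecule they left unchanged, and here five carbons in a ring in place of a single carbon go with a lower number, not a higher one. No measurement shown explains why this change has so large an effect.

On these data alone, with only methyl and cyclopentyl on this oxygen, it remains open whether a smaller ring such as cyclopropyl, an open chain such as isobutyl, or a chain ending in an amine would also give a lower number. As far as these compounds go, it also remains open whether the same swap would produce a step of similar size with the 2,3-dichlorophenyl of compound 2 or the pyrimidin-2-yl of compound 3 on the amine nitrogen in the ring.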